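The source may report more compounds than this note shows. Statements on the series, on what has been measured and on what is new or still open speak of the compounds shown alone.

Values in a functional assay on the whole organism (strain C57Bl/6) for inhibition, with Mus musculus as the target, with a stated time of 180 min, at 48 degrees C (a lower number here means that less compound is needed, a higher number that more compound is needed for the effect), for the measured members of the series:

compound 1 `COc1ccc(Cn2c(=O)nc(NCCNC(=N)N)n(Cc3ccc(Br)cc3)c2=O)cc1`: 0.0043 nM
compound 2 `COc1ccc(Cn2c(NCCNC(=N)N)nc(=O)n(Cc3ccc(Cl)cc3)c2=O)cc1`: 0.004 nM
compound 3 `COc1ccc(Cn2c(NCCNC(=N)N)nc(=O)n(Cc3ccc(F)cc3)c2=O)cc1`: 0.00031 nM

Compound 1 stands at the highest of the three numbers. Compound 2 sits within the usual scatter of it, so no order between the two can be read. Within the data shown here, compound 3 lies beyond the scatter, and the single one-point step in the set, a 13-fold lower number from compound 2 to compound 3 (1.11 log units; beyond the scatter), is the change of fluoro in place of chloro on an aromatic carbon.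

Compound 4 `COc1ccc(Cn2c(=O)nc(NCCNC(=N)N)n(Cc3ccc(Cl)c(Cl)c3)c2=O)cc1` has not been measured in this assay. It differs from compound 1 by 3,4-dichlorophenyl in place of 4-bromophenyl on a saturated chain carbon bound to an aromatic nitrogen. The measured step bears on this only loosely: it swaps one halogen for another on the same benzyl group, and the pair compound 1 and compound 2, bromo against chloro, shows no step beyond the scatter. Among the measured compounds shown here, no measured pair goes from 4-bromophenyl to 3,4-dichlorophenyl, so there is no direct precedent. The expectation is therefore a step within the scatter, a 1.2-fold higher number from compound 1 to compound 4 (0.07 log units; within the scatter), with compound 4 estimated at 0.005 nM in a range of 0.0015 nM to 0.02 nM.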

Compound 4, half-maximal effective concentration: 0.0045 nM
Compound 4: middle estimate off by 1.1-fold (0.05 log units), on the high side; the measured number falls inside the stated range.
By their numbers in this assay, from the lowest: compound 3; then compounds 2, 1 and 4 (each within the scatter of the next).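

In this assay, 3,4-dichlorophenyl in place of 4-bromophenyl on a saturated chain carbon bound to an aromatic nitrogen gives a 1.0-fold higher number from compound 1 to compound 4 (0.02 log units; within the scatter) and so stays within the scatter. Until now this place had held only groups with a single halogen, and this pair shows that a group of 8 heavy atoms with 2 chlorine can stand in place of one of 7 heavy atoms with 1 bromine with no readable difference. Nothing available gives a reason for this result.

Still open, from the compounds shown here alone, is whether 4-fluorophenyl at this place on the core of compound 1 would reach the low number of compound 3. Also open, going by these compounds, is how a phenyl ring bearing a carboxylic acid or an amine would read at this place.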